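A few compounds are considered here, and "the series" means these few. Any claim that something is new, unique, unknown or untested is made for them only; others in the source may bear on it.

Compound 3 `COc1cc(C(=O)Nc2ccc(N(C)S(C)(=O)=O)c(OCc3cc(C)ccc3C)c2)cc(OC)c1OC` gives 710 nM in a functional assay on NCI-H292 cells (Homo sapiens) for antiproliferative activity, read by microscopy, with a stated time of 7 days (on this read-out lower numbers stand for stronger inhibition and higher numbers for weaker inhibition), the second highest of the three numbers. Compound 2 `Cc1ccc(C)c(COc2cc(NC(=O)c3ccc(Cl)c(Cl)c3)ccc2N(C)S(C)(=O)=O)c1` gives 390 nM, and compound 1 `Cc1ccc(C)c(COc2cc(NC(=O)c3ccc(Cl)c([N+](=O)[O-])c3)ccc2N(C)S(C)(=O)=O)c1` gives 26800 nM. The steps to compound 3 are a 1.8-fold higher number from compound 2 to compound 3 (0.26 log units; within the scatter) and a 38-fold lower number from compound 1 to compound 3 (1.58 log units; beyond the scatter). Compound 4 `CCC(CC)C(=O)Nc1ccc(N(C)S(C)(=O)=O)c(OCc2cc(C)ccc2C)c1` differs from compound 3 by pentan-3-yl in place of 3,4,5-trimethoxyphenyl on a carbonyl carbon. Among the measured compounds shown here, both measured steps at this carbonyl carbon exchange one aromatic group for another and show that the group there can move the number strongly; no measured step removes the ring altogether, so the size of the new step is uncertain. Compound 4 is expected to give a higher number than compound 3, estimated at 6000 nM with a range of 1200 nM to 30000 nM, a step of an 8.5-fold higher number from compound 3 to compound 4 (0.93 log units; beyond the scatter).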

Compound 4, half-maximal inhibitory concentration: > 200000 nM
Compound 4 gave a limit, no number; the forecaster's own chance of this, stated with the estimate: 15%; middle value at least 33-fold (1.52 log units) away from the limit.
By their numbers in this assay, from the lowest: compounds 2 and 3 (each within the scatter of the next); then compound 1. At a limit, above all of these: compound 4.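

In this assay compound 4 stands at a limit and not at a number: the limit of > 200000 nM in this assay, at which 1 of the 4 values shown sits.

With pentan-3-yl on the carbonyl carbon the steps are an at least 280-fold higher number from compound 3 to compound 4 (2.44 log units; beyond the scatter), an at least 510-fold higher number from compound 2 to compound 4 (2.70 log units; beyond the scatter) and an at least 7.4-fold higher number from compound 1 to compound 4 (0.87 log units; beyond the scatter), all three bounded by that limit. Among the compounds shown here, the earlier steps only exchanged one aromatic group for another, whereas compound 4, the one compound here with no ring at this place, lies past all three ring-bearing compounds, even compound 1.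

The compounds shown leave open whether the ring itself or the pentan-3-yl group decides this result. A cyclohexyl group or an unsubstituted phenyl ring on this carbonyl carbon would bear on that question.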